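The source may report more compounds than this note shows. Statements on the series, on what has been measured and on what is new or still open speak of the compounds shown alone.

Compound 1 `CS(=O)(=O)Nc1cccc(-c2nc(C(c3ccc(F)cc3)c3ccc(F)cc3)sc2CC(=O)O)c1`: 80%
Compound 2 `CCC(c1ccccc1)c1nc(-c2ccc(Cl)cc2)c(CC(=O)O)s1`: 50%

Of the compounds shown here, two have so far been measured in an in vitro functional assay on HEK285-7 cells for antagonist activity at prostaglandin D2 receptor 2 (Homo sapiens), read by BRET and beta-arrestin recruitment; a higher number here means a larger maximal response, a lower number a smaller maximal response. Of these, compound 1 gives 80% and stands highest, while compound 2 gives 50%, a number lower by a margin that lies beyond the usual scatter of this kind of measurement. Going by the values given here, no pair of measured compounds differs in only one place, so no measured step is available to guide the next change.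

Compound 3 `NS(=O)(=O)c1cccc(-c2nc(C(c3ccc(F)cc3)c3ccc(F)cc3)sc2CC(=O)O)c1` has not yet been measured in this assay. It differs from compound 1 in a single place: sulfamoyl in place of methanesulfonamido on an aromatic carbon. The change sits on an aromatic carbon of the shared core, with the rest of compound 1 kept as it is.

Among the compounds with values here, with no measured step of this kind to rest on, the step of a number 5 percentage points lower from compound 1 to compound 3 (within the scatter) is expected to be small, most likely within the scatter, with its direction uncertain. Compound 3 is accordingly estimated at 75%, with a range from 55% to 95%.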

Compound 3, largest response reached (reported as efficacy), in percent of the reference or control that the assay uses: 55%
For compound 3 the middle estimate is 20 percentage points above the measured one; measured number inside the range.
By their numbers in this assay, from the lowest: compounds 2 and 3 (each within the scatter of the next); then compound 1.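

Going by these compounds alone, replacing the methanesulfonamido group with sulfamoyl on this aromatic carbon gives a number 25 percentage points lower from compound 1 to compound 3 (beyond the scatter) in this assay and provides the first measured step at this position. The response therefore depends on which group sits here, even though the two groups match in hydrogen-bond donors and acceptors, carry no net charge and differ by the carbon that leaves with the methanesulfonamido group. Nothing in the data explains why this change lowers the response.

With a single step at this position, the compounds shown cannot separate the loss of that carbon from the change in how the sulfonyl group is attached to the ring. They also leave open how an amine, a carboxylic acid or an acetamido group would behave on this aromatic carbon with the rest of compound 1 kept as it is.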